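Notes on two sulfonamides and one unmeasured analogue

A few compounds are considered here, and "the series" means these few. Any claim that something is new, unique, unknown or untested is made for them only; others in the source may bear on it.

Compound 1 `O=S(=O)(Nc1ccc(-c2nc3ccccc3o2)cc1)c1ccccc1O` is the reference point of these notes. In an assay on isolated protein for inhibition of malate dehydrogenase, mitochondrial (Sus scrofa), with stated times of 45 min and 30 min (on this read-out lower numbers stand for stronger inhibition and higher numbers for weaker inhibition), compound 1 returns only a limit, > 63000 nM, and no number stands for it. Compound 2 `COc1ccc(S(=O)(=O)Nc2ccc3oc(-c4ccccc4)nc3c2)cc1` likewise gives only a limit in this assay, > 63000 nM. For the measured compounds named here, every measured value therefore sits at the limit of > 63000 nM in this assay, at which 2 of the 2 values shown sit, so no step between measured compounds can be read, and the series so far shows no direction of any kind.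

Compound 3 `COc1cccc(S(=O)(=O)Nc2ccc(-c3nc4ccccc4o3)cc2)c1` is not yet measured. It differs from compound 1 in one place: 3-methoxyphenyl in place of 2-hydroxyphenyl on a sulfonyl sulfur. Nothing measured in the series speaks to a 3-methoxyphenyl on the sulfonyl sulfur, and the 2-hydroxyphenyl of compound 1 itself gave no number.

With both known values at a limit, the expected step in this assay is a step that the limit leaves unreadable from compound 1 to compound 3, nothing beyond the scatter. Compound 3 is accordingly estimated at 80000 nM, with a range from 20000 nM to 300000 nM, and most probably it too will come back as a limit rather than a number.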

Compound 3, half-maximal inhibitory concentration: > 63000 nM
Compound 3: only a limit was reported; the forecaster's own chance of this, stated with the estimate: 80%; the middle value lies beyond the limit too.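

In this assay compound 3 returns only a limit, > 63000 nM. No step from compound 1 to compound 3 can be read, and the series still holds no number: the limit of > 63000 nM in this assay, at which 3 of the 3 values shown sit.

The compounds shown leave open whether 3-methoxyphenyl in place of 2-hydroxyphenyl on a sulfonyl sulfur changes inhibition at all in this assay.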